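Shifting the nitrile on the aryl ring of compound 3

A few compounds are considered here, and "the series" means these few. Any claim that something is new, unique, unknown or untested is made for them only; others in the source may bear on it.

Three compounds share one core and differ only in the aryl group on the aromatic nitrogen. Compound 1 `CC1(C)[C@H]2CC[C@]1(C)N(Cc1cn(-c3ccccc3Br)nn1)C(=O)C2` gives 280 nM in a functional assay on PANC-1 cells (Homo sapiens) for inhibition, read by MTT assay, with a stated time of 24 h; on this read-out lower numbers stand for stronger inhibition and higher numbers for weaker inhibition. Compound 2 `CC1(C)[C@H]2CC[C@]1(C)N(Cc1cn(-c3ccc(C#N)cc3)nn1)C(=O)C2` gives 250 nM in this assay, and compound 3 `CC1(C)[C@H]2CC[C@]1(C)N(Cc1cn(-c3ccccc3C#N)nn1)C(=O)C2` gives 240 nM. Compound 3 has the lowest of the three numbers, but its steps to the others are small: a 1.2-fold lower number from compound 1 to compound 3 (0.07 log units; within the scatter) and a 1.0-fold lower number from compound 2 to compound 3 (0.02 log units; within the scatter), both within the scatter, as is a 1.1-fold lower number from compound 1 to compound 2 (0.05 log units; within the scatter).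

Compound 4 `CC1(C)[C@H]2CC[C@]1(C)N(Cc1cn(-c3cccc(C#N)c3)nn1)C(=O)C2` is not yet measured. It differs from compound 3 as follows: 3-cyanophenyl in place of 2-cyanophenyl on an aromatic nitrogen. Going by the values given here, the step that bears most directly on this is the one from compound 2 to compound 3, where the cyano group moved between two positions on the same ring and the number barely changed: a 1.0-fold lower number from compound 2 to compound 3 (0.02 log units; within the scatter). Among the compounds with values here, nothing among the measured compounds shows that where the cyano sits on the ring matters. Compound 4 is therefore expected to give a number like that of compound 3, with a 1.0-fold higher number from compound 3 to compound 4 (0.02 log units; within the scatter) expected to lie within the scatter. For compound 4 the estimate in this assay is 250 nM, with a range from 130 nM to 500 nM.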

Compound 4, half-maximal inhibitory concentration: 260 nM
Estimate against measurement, compound 4: 1.0-fold (0.02 log units) below; the measured number falls inside the stated range.
By their numbers in this assay, from the lowest: compounds 3, 2, 4 and 1 (each within the scatter of the next).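

Compound 4 completes the set of 2-cyanophenyl, 3-cyanophenyl and 4-cyanophenyl groups on the aromatic nitrogen, and in this assay the nitrile's place on this ring makes no difference that can be read (a 1.1-fold higher number from compound 3 to compound 4 (0.03 log units; within the scatter); a 1.0-fold higher number from compound 2 to compound 4 (0.02 log units; within the scatter)). The 3-cyanophenyl group also reads level with the 2-bromophenyl group (a 1.1-fold lower number from compound 1 to compound 4 (0.03 log units; within the scatter)), so across these four compounds no aryl group on this nitrogen stands apart from the others. Nothing given here accounts for this flat result.

On these data alone, all four compounds carry a nitrile or a bromo group on a phenyl ring, so it remains open whether an amine or a carboxylic acid on that ring would shift the number. As far as these compounds go, it is equally open what a butyl chain would give in place of the whole aryl group.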